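Methyl on the Terminal Phenyl: From Compound 1 to Compound 4

A few compounds are considered here, and "the series" means these few. Any claim that something is new, unique, unknown or untested is made for them only; others in the source may bear on it.

Measured so far in a functional assay on T-24 cells (Homo sapiens) for antiproliferative activity, read by MTT assay, with a stated time of 48 h; on this read-out lower numbers stand for stronger inhibition and higher numbers for weaker inhibition:
- compound 1, `O=C(Nc1ccccc1)Nc1cccc(CNc2nccnc2Cl)c1`, gives 19800 nM
- compound 2, `O=C(Nc1cccc(CNc2nccnc2Cl)c1)Nc1ccc(Cl)cc1Br`, gives 6650 nM
- compound 3, `O=C(Nc1cccc(CNc2nccnc2Cl)c1)Nc1ccc(F)c(Cl)c1`, gives 4990 nM

Compound 1 has the highest number of the three, so it is the weakest inhibitor of cell growth in this set. The step of a 3.0-fold lower number from compound 1 to compound 2 (0.47 log units; beyond the scatter) and the step of a 4.0-fold lower number from compound 1 to compound 3 (0.60 log units; beyond the scatter) both come from exchanging the plain phenyl on one urea nitrogen for a phenyl carrying two substituents, and both lower the number beyond the scatter. Compound 2 and compound 3 sit within the scatter of each other: a 1.3-fold lower number from compound 2 to compound 3 (0.12 log units; within the scatter).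

Compound 4, `Cc1cccc(NC(=O)Nc2cccc(CNc3nccnc3Cl)c2)c1`, is not yet measured. It differs from compound 1 by methyl in place of hydrogen on an aromatic carbon. Among the measured compounds shown here, no measured step adds a lone methyl; the two steps from compound 1 add chloro, bromo or fluoro groups instead, so they bear on this change only loosely. Both point the same way, downward, and a single small group is expected to do less than two. The expected change in this assay is a 1.8-fold lower number from compound 1 to compound 4 (0.26 log units; within the scatter), a small lowering that may not clear the scatter. Compound 4 is therefore estimated at 11000 nM, with a range from 4500 nM to 27000 nM.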

Compound 4, half-maximal inhibitory concentration: 9570 nM
Compound 4: middle estimate off by 1.1-fold (0.06 log units), on the high side; measured number inside the range.
By their numbers in this assay, from the lowest: compounds 3, 2 and 4 (each within the scatter of the next); then compound 1.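

In this assay, a single methyl on the terminal ring is enough to take the number beyond the scatter, with a 2.1-fold lower number from compound 1 to compound 4 (0.32 log units; beyond the scatter) as the step, so a halogen on this ring is not needed for a measurable lowering. The 3-methylphenyl group adds only one carbon to the phenyl of compound 1, yet compound 4 cannot be told apart from the compounds with two halogens on that ring: a 1.9-fold higher number from compound 3 to compound 4 (0.28 log units; within the scatter) and a 1.4-fold higher number from compound 2 to compound 4 (0.16 log units; within the scatter) both stay within the scatter, so these numbers give no ranking among the three substituted rings. No measurement in hand explains why adding this methyl shifts the number.

The compounds shown carry a methyl at only one place on the ring, so they leave open whether the same group would give a similar step elsewhere on it. They also leave open whether a longer chain such as ethyl, or a methoxy group or an amine at the same place, would lower the number further, leave it unchanged or raise it.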